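This account rests on a few compounds, and the source may have more. Where it says the series, first, only, none or still open, it means among the compounds named here.

- compound 1 `Cc1ccc(NC2=CC(=O)c3c(nc4n3[C@H]3OC[C@@H](O)[C@H]3OC4)C2=O)cc1`: 1550 nM
- compound 2 `CCc1ccc(NC2=CC(=O)c3nc4n(c3C2=O)[C@H]2OC[C@@H](O)[C@H]2OC4)cc1`: 1290 nM

In a functional assay on MGC-803 cells (Homo sapiens) for inhibition, read by sulforhodamine B assay (on this read-out higher numbers stand for weaker inhibition and lower numbers for stronger inhibition), compound 1 gives 1550 nM, and compound 2 gives 1290 nM, so the two lie within the usual scatter of each other. Compound 3 `COc1ccc(NC2=CC(=O)c3c(nc4n3[C@H]3OC[C@@H](O)[C@H]3OC4)C2=O)cc1` keeps the core of compound 1 and carries methoxy in place of methyl on an aromatic carbon, para to a large group (methoxy in place of methyl on an aromatic carbon). Among the measured compounds shown here, no measured pair shows this change, so no step beyond the scatter is expected in this assay, in either direction. Compound 3 is expected near 1400 nM, with an estimated range of 620 nM to 3100 nM.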

Compound 3, half-maximal inhibitory concentration: 2150 nM
Beside the measured number, compound 3's estimate is 1.5-fold (0.19 log units) below it; the range from low to high includes it.
By their numbers in this assay, from the lowest: compounds 2, 1 and 3 (each within the scatter of the next).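

Placing methoxy in place of methyl on an aromatic carbon, para to a large group, gives a 1.4-fold higher number from compound 1 to compound 3 (0.14 log units; within the scatter) in this assay and so adds the first measured step at this position. This position takes methoxy as well as methyl, with one more heavy atom and one hydrogen-bond acceptor added, and the step stays within the usual scatter. No supporting measurement bears on this result.

Still open, as far as these compounds go, is whether an amine or a carboxylic acid on this carbon would give a step beyond the scatter.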